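Shifting the hydroxyl pattern on the arylidene hydrazide

This account rests on a few compounds, and the source may have more. Where it says the series, first, only, none or still open, it means among the compounds named here.

Compound 1 `Cc1c(C(=O)N/N=C\c2cccc(F)c2)oc2cccc(O)c12` is measured only as a limit in a functional assay on PC-3 cells (Homo sapiens) for inhibition (on this read-out lower numbers stand for stronger inhibition and higher numbers for weaker inhibition), where compound 1 gives >= 40000 nM (the limit of >= 40000 nM in this assay, at which 1 of the 3 values shown sits). Compound 2 `Cc1c(C(=O)N/N=C\c2cccc(O)c2O)oc2cccc(O)c12` gives 12200 nM and compound 3 `Cc1c(C(=O)N/N=C\c2c(O)cccc2Cl)oc2cccc(O)c12` gives 18700 nM; the change from compound 1 gave an at least 3.2-fold lower number from compound 1 to compound 2 (0.51 log units; beyond the scatter) and an at least 2.1-fold lower number from compound 1 to compound 3 (0.33 log units; beyond the scatter), while a 1.5-fold higher number from compound 2 to compound 3 (0.19 log units; within the scatter) leaves compound 3 with the higher of the two numbers, though within the scatter of compound 2. Compound 4 `Cc1c(C(=O)N/N=C\c2cccc(F)c2O)oc2cccc(O)c12` differs by 3-fluoro-2-hydroxyphenyl in place of 2-chloro-6-hydroxyphenyl on a carbon with a double bond to nitrogen, keeping the hydroxyl seen in compound 2 and compound 3 and the fluorine of compound 1. Since the two hydroxylated aryl groups gave a 1.5-fold higher number from compound 2 to compound 3 (0.19 log units; within the scatter), no step beyond the scatter is expected here. Compound 4 is therefore expected to give about 16000 nM, with a range from 6000 nM to 40000 nM. The expected step is a 1.2-fold lower number from compound 3 to compound 4 (0.07 log units; within the scatter).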

Compound 4, half-maximal inhibitory concentration: 12700 nM
Compound 4: middle estimate off by 1.3-fold (0.10 log units), on the high side; measured number inside the range.
By their numbers in this assay, from the lowest: compounds 2, 4 and 3 (each within the scatter of the next). At a limit, above all of these: compound 1.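

Hydroxy in place of hydrogen on an aromatic carbon, with the fluorine kept, is enough for an at least 3.1-fold lower number from compound 1 to compound 4 (0.49 log units; beyond the scatter), and this size is only a bound, as compound 1 stands at a limit: the limit of >= 40000 nM in this assay, at which 1 of the 4 values shown sits.

Fluoro in place of hydroxy on an aromatic carbon gives a 1.0-fold higher number from compound 2 to compound 4 (0.02 log units; within the scatter), so compound 4 shows that the second hydroxyl of compound 2 is not required. The aryl exchange gives a 1.5-fold lower number from compound 3 to compound 4 (0.17 log units; within the scatter), which leaves the halogen choice unresolved in this assay.

Going by these compounds, whether a methoxy group or an amine could stand in for the hydroxyl remains open.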